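Swapping fluoro for methyl beside a methylsulfonyl group

The compounds below may be only part of what the source reports. "The series", "measured", "known", "first", "only" and "open" are said of these compounds alone.

Measured compounds in an assay for binding affinity to Alpha-1A adrenergic receptor (Homo sapiens), read by radioligand binding; on this read-out lower numbers stand for stronger inhibition and higher numbers for weaker inhibition:
- compound 1 `COc1ccc(S(C)(=O)=O)c(NCC2=NCCN2)c1`: 1620 nM
- compound 2 `CSc1ccc(C)cc1NCC1=NCCN1`: 20.9 nM
- compound 3 `CS(=O)(=O)c1ccc(F)cc1NCC1=NCCN1`: 813 nM

Compound 3 stands second highest of the three numbers; its nearest neighbour is compound 1, and compound 2 lies furthest from it, with a number lower beyond the scatter. Compound 4 `Cc1ccc(S(C)(=O)=O)c(NCC2=NCCN2)c1` is not yet measured. It differs from compound 3 by methyl in place of fluoro on an aromatic carbon. Within the data shown here, the only measured step at the same position is a 2.0-fold lower number from compound 1 to compound 3 (0.30 log units; within the scatter), which stayed within the scatter. Compound 2 carries a methyl too, but it is not linked to compound 4 by a single change, so its number cannot be read as a step. For compound 4 a modest move to a lower number is expected, a 1.8-fold lower number from compound 3 to compound 4 (0.26 log units; within the scatter), giving an estimate of 450 nM with a range from 150 nM to 1500 nM.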

Compound 4, inhibition constant: 776 nM
Estimate against measurement, compound 4: 1.7-fold (0.24 log units) below; low and high end bracket the measured number.
By their numbers in this assay, from the lowest: compound 2; then compounds 4, 3 and 1 (each within the scatter of the next, the first and the last beyond it).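

In (this assay) methyl and fluoro at this position, para to a methylsulfonyl group, cannot be told apart (a 1.0-fold lower number from compound 3 to compound 4 (0.02 log units; within the scatter)). Methyl in place of methoxy gives a modest step (a 2.1-fold lower number from compound 1 to compound 4 (0.32 log units; beyond the scatter)), whereas methylsulfonyl in place of methylsulfanyl gives a far larger one (a 37-fold higher number from compound 2 to compound 4 (1.57 log units; beyond the scatter)), so among these compounds the sulfur group matters more than this position does. No evidence here explains either result. On these data alone, whether an amine or a carboxylic acid at this position would shift the number remains open, as does whether the large sulfur step would recur with fluoro or methoxy on the ring.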